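This account rests on a few compounds, and the source may have more. Where it says the series, first, only, none or still open, it means among the compounds named here.

Of the compounds shown here, two sharing one core have been measured so far in an ADME assay on a cell-free system (plasma, Homo sapiens) for metabolic stability, read by HPLC; on this read-out lower numbers stand for a shorter-lived compound and higher numbers for a longer-lived compound. Compound 1 (`CCCC(=O)N(C)/N=N/c1ccc(C#N)cc1`) gives 15.2 h, and compound 2 (`CC(C)C(=O)N(C)/N=N/c1ccc(C#N)cc1`) gives 13.9 h, so compound 2 stands level with compound 1 within the usual scatter of such measurements. The next structure is compound 3 (`CCC(CC)C(=O)N(C)/N=N/c1ccc(C#N)cc1`), which differs from compound 2 in a single group: pentan-3-yl in place of isopropyl on a carbonyl carbon. Put simply, pentan-3-yl takes the place of isopropyl on a carbonyl carbon.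

Among the compounds with values here, only one measured step bears on this change, because it alters the group at that same place: a 1.1-fold lower number from compound 1 to compound 2 (0.04 log units; within the scatter). There, isopropyl replaced propyl, and the result stayed within the scatter. Within the data shown here, a single small step is thin evidence, and no measured compound yet carries pentan-3-yl. Even so, nothing measured so far points to a shift in either direction, so no change beyond the scatter is expected in this assay. The estimated step is a 1.1-fold higher number from compound 2 to compound 3 (0.03 log units; within the scatter). For compound 3, the estimated half-life is 15 h, with an expected range from 8 h to 28 h.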

Compound 3, half-life in the Homo sapiens assay: > 40 h
Compound 3 ended at the assay's limit (the forecaster's own chance of this, stated with the estimate: 5%); middle value at least 2.6-fold (0.42 log units) away from the limit.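

In the Homo sapiens assay, the earlier change on the carbonyl carbon, isopropyl in place of propyl, stayed within the scatter, but pentan-3-yl at this same place gives a clear step: an at least 2.8-fold higher number from compound 2 to compound 3 (0.45 log units; beyond the scatter), and likewise an at least 2.6-fold higher number from compound 1 to compound 3 (0.42 log units; beyond the scatter). So the group on the carbonyl carbon can make a real difference to half-life in this plasma read-out, even though the change adds only carbon, with 5 heavy atoms in pentan-3-yl against 3 heavy atoms in isopropyl, and neither group carries a ring, a hydrogen-bond donor, a hydrogen-bond acceptor or a net charge. In the Homo sapiens assay compound 3 gives > 40 h, which is a limit of the assay and not a number, so both steps give only a lowest size: the limit of > 40 h in the Homo sapiens assay, at which 1 of the 3 values shown sits.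

In a physicochemical assay for pharmacokinetics, read by HPLC, in phosphate buffer, at pH 7.4 (on this read-out lower numbers stand for a shorter-lived compound and higher numbers for a longer-lived compound), compound 2 gives > 40 h, which is a limit of the assay and not a number. In the physicochemical assay compound 3 gives > 40 h, which is also a limit of the assay and not a number. In the physicochemical assay compound 2 and compound 3 both sit at a limit, so the step between them cannot be read: the limit of > 40 h in the physicochemical assay, at which 2 of the 2 values shown sit. Whether a cyclohexyl group or a longer chain on the carbonyl carbon would also give a longer half-life in the Homo sapiens assay stays open, and so does the reason for the step from isopropyl to pentan-3-yl.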